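The source may hold more compounds than are shown below. What is called first, only, known or untested is meant among the compounds shown, and "the series" means these compounds.

Three analogues of one shared core have been measured in an assay on isolated protein (strain Sprague-Dawley) for inhibition of Amine oxidase [flavin-containing] A (Rattus norvegicus), read by spectrophotometry, with a stated time of 5 min, tested at 10 uM; on this read-out lower numbers stand for less inhibition and higher numbers for more inhibition at the one concentration tested (going by the name of the read-out). Compound 1 `COCOc1cc(=O)oc2cc(OCc3cccc(Cl)c3)ccc12` gives 23% in this assay. Compound 2 `CCOC(=O)COc1cc(=O)oc2cc(OCc3cccc(Cl)c3)ccc12` gives 0%, and compound 3 `CN(C)C(=O)COc1cc(=O)oc2cc(OCc3cccc(Cl)c3)ccc12` gives 10%. Compound 3 stands second highest of the three numbers: its nearest neighbour is compound 2, the gap being a number 10 percentage points higher from compound 2 to compound 3 (within the scatter), and the furthest is compound 1, the gap being a number 13 percentage points lower from compound 1 to compound 3 (beyond the scatter). The remaining measured step is a number 23 percentage points lower from compound 1 to compound 2 (beyond the scatter).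

The next compound, compound 4 `CCOC(=O)c1cc(=O)oc2cc(OCc3cccc(Cl)c3)ccc12`, differs from compound 3 in one place: ethoxycarbonyl in place of (dimethylcarbamoyl)methoxy on an aromatic carbon. Among the measured compounds shown here, no measured step removes the saturated chain carbon and the oxygen that join a group to the aromatic ring; the three steps above exchange only what sits on that chain. Within those, compound 2 at 0% and compound 3 at 10% both carry a carbonyl on the chain and both sit low, with the step between them within the scatter. The expected step in this assay is therefore a number 2 percentage points lower from compound 3 to compound 4 (within the scatter), small and with no direction secured beyond the scatter, though a low reading seems the more likely. Compound 4 is accordingly estimated at 8%, with a range from 0% to 25%.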

Compound 4, a percentage reported as inhibition, at one concentration (the size of the read-out at that concentration, not a potency): 4.4%
Beside the measured number, compound 4's estimate is 3.6 percentage points above it, and the stated range covers the measured number.
By their numbers in this assay, from the lowest: compounds 2, 4 and 3 (each within the scatter of the next); then compound 1.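

Working notes on the position opposite the ring oxygen. In this assay, among the compounds shown here, compound 4 is the first analogue with a carbonyl on the aromatic carbon itself, without the saturated chain carbon and oxygen link, yet a number 5.6 percentage points lower from compound 3 to compound 4 (within the scatter) and a number 4.4 percentage points higher from compound 2 to compound 4 (within the scatter) leave it unseparated from the two compounds with a chain-borne carbonyl. Removing that link therefore shows no effect beyond the scatter in these comparisons, while a number 18.6 percentage points lower from compound 1 to compound 4 (beyond the scatter) means that compound 1, with methoxymethoxy, now stands clear of all three carbonyl-bearing analogues, and no listed compound goes against this grouping. No supporting measurement bears on why the readings fall this way.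

From the compounds shown here alone, whether the separation of compound 1 belongs to the absence of a carbonyl or to some other feature of methoxymethoxy remains open, and a carbonyl-free ether such as ethoxymethoxy or a longer alkoxy chain at this position would test that. A carboxylic acid or a primary amine on the same aromatic carbon would also show whether this position can carry a reading above that of compound 1, since the shown series offers only esters, a tertiary amide and one acetal-type ether.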